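A few compounds are considered here, and "the series" means these few. Any claim that something is new, unique, unknown or untested is made for them only; others in the source may bear on it.

Measured so far in a functional assay on NCI-H460 cells (Homo sapiens) for inhibition, read by sulforhodamine B assay, with a stated time of 48 h; on this read-out higher numbers stand for weaker inhibition of growth and lower numbers for stronger inhibition of growth:
- compound 1 `O=C(NNC(=O)c1ccc2[nH]c(-c3ccc([N+](=O)[O-])o3)nc2c1)c1ccccc1`: 62.5 ug/mL
- compound 2 `COc1cc(C(=O)NNC(=O)c2ccc3[nH]c(-c4ccc([N+](=O)[O-])s4)nc3c2)cc(OC)c1OC`: 62.5 ug/mL
- compound 3 `O=CNNC(=O)c1ccc2[nH]c(-c3ccc([N+](=O)[O-])o3)nc2c1`: 31.3 ug/mL

Compound 1 stands level with compound 2 at the digits shown, and compound 3 lies within the scatter of it. The next structure is compound 4 `O=C(NNC(=O)c1ccc2[nH]c(-c3ccc([N+](=O)[O-])o3)nc2c1)c1cccc(Oc2ccccc2)c1`, reached by phenoxy in place of hydrogen on an aromatic carbon. For the measured compounds named here, no measured step adds a group at this place. Going by the values given here, the one step that alters the phenyl of compound 1 is a 2.0-fold lower number from compound 1 to compound 3 (0.30 log units; within the scatter), which stays within the scatter. Thin as this evidence is, no change beyond the scatter is expected in this assay. The expected step is a 1.3-fold lower number from compound 1 to compound 4 (0.10 log units; within the scatter). For compound 4 the estimate is 50 ug/mL, with an expected range from 15.6 ug/mL to 125 ug/mL.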

Compound 4, concentration for 50% growth inhibition: > 7.8 ug/mL
Compound 4: a limit, no number; the forecaster's own chance of this, stated with the estimate: 15%; the middle value does not contradict the limit.
By their numbers in this assay, from the lowest: compounds 3, 1 and 2 (each within the scatter of the next).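

Compound 4 gives a limit, > 7.8 ug/mL, and no number; the step from compound 1 to compound 4 cannot be read. From the compounds shown here alone, whether phenoxy in place of hydrogen on an aromatic carbon changes growth inhibition in this assay stays open.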